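From chloro to methoxy: what compound 4 may show

The compounds below may be only part of what the source reports. "The series", "measured", "known", "first", "only" and "open" are said of these compounds alone.

Measured in an ADME assay on MDBK cells (Bos taurus) for cytotoxicity, read by MTT assay, with a stated time of 96 h; on this read-out lower numbers stand for higher toxicity in this test and higher numbers for lower toxicity in this test:
- compound 1 `COc1ccc(-c2nc3cc(/C(C)=N/NC(N)=O)ccc3[nH]2)cc1` gives 25000 nM
- compound 2 `C/C(=N\NC(N)=S)c1ccc2[nH]c(-c3ccccc3)nc2c1` gives 32000 nM
- compound 3 `C/C(=N\NC(N)=S)c1ccc2[nH]c(-c3ccc(Cl)cc3)nc2c1` gives > 100000 nM, which is a limit and not a number

Compound 3 has no exact value and stands at the limit of > 100000 nM in this assay, at which 1 of the 3 values shown sits. Compound 4 `COc1ccc(-c2nc3cc(/C(C)=N/NC(N)=S)ccc3[nH]2)cc1` is not yet measured. It differs from compound 3 by one exchange, methoxy in place of chloro on an aromatic carbon.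

Going by the values given here, one measured step bears directly on this position, where chloro replaced hydrogen: an at least 3.1-fold higher number from compound 2 to compound 3 (0.49 log units; beyond the scatter). Among the compounds with values here, removing the chloro may therefore bring the number down, although no step from hydrogen to methoxy has been measured. Though not otherwise identical to compound 4, compound 1 already carries the methoxy group and gives 25000 nM. Compound 2, which has hydrogen there, gives 32000 nM. Both suggest that a measurable number is likely rather than another limit.

The expected change, towards a lower number and so higher toxicity in this test, is an at least 2.5-fold lower number from compound 3 to compound 4 (0.39 log units; beyond the scatter). For compound 4 the estimated value is 40000 nM, with an expected range from 15000 nM to 100000 nM.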

Compound 4, half-maximal cytotoxic concentration: 13000 nM
The estimate for compound 4 lay 3.1-fold (0.49 log units) above the measured number; measured number outside the range, below it.
By their numbers in this assay, from the lowest: compounds 4, 1 and 2 (each within the scatter of the next, the first and the last beyond it). At a limit, above all of these: compound 3.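

In this assay, exchanging chloro for methoxy at this position gives an at least 7.6-fold lower number from compound 3 to compound 4 (0.88 log units; beyond the scatter), and that size is only a minimum because compound 3 sits at a limit: the limit of > 100000 nM in this assay, at which 1 of the 4 values shown sits. The position now responds in two directions, since chloro in place of hydrogen gives an at least 3.1-fold higher number from compound 2 to compound 3 (0.49 log units; beyond the scatter), while methoxy in place of hydrogen gives a 2.5-fold lower number from compound 2 to compound 4 (0.39 log units; beyond the scatter), so the two groups move the number in opposite ways from the same starting point. With methoxy in place, exchanging the oxygen-bearing group on the amine nitrogen for the sulfur-bearing one gives a 1.9-fold lower number from compound 1 to compound 4 (0.28 log units; within the scatter), so this exchange cannot be told apart from the usual scatter of the test.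

Only hydrogen, chloro and methoxy are shown at this position, so it remains open where other groups, such as fluoro, an amine or a carboxylic acid, would fall, and whether any general trend exists. Going by these compounds, it also remains open whether the exchange of oxygen for sulfur would stay as small with chloro or hydrogen at this position, and how far the true number of compound 3 lies from its limit.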